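The source may hold more compounds than are shown below. What is called first, only, known or untested is meant among the compounds shown, and "the series" means these compounds.

The shared core of compound 1 `CN1CCC(C(=O)N2Cc3c(NC(=O)c4ccsc4)n[nH]c3C2(C)C)CC1` carries a thiophen-3-yl group on a carbonyl carbon. In a physicochemical assay for solubility, at pH 7 (on this read-out higher numbers stand for higher solubility and lower numbers for lower solubility), compound 1 gives > 225000 nM, which is a limit of the assay rather than a number. Compound 2 `CN1CCC(C(=O)Nc2n[nH]c3c2CN(C(=O)C(C)(C)C)C3(C)C)CC1` is a second member of the set. In this assay compound 2 gives > 225000 nM, again a limit of the assay. Compound 3 `CC(=O)N1CCN(C(=O)N2Cc3c(NC(=O)c4ccc(F)cc4)n[nH]c3C2(C)C)CC1` completes the measured set. In this assay compound 3 gives > 225000 nM, also a limit of the assay. For the measured compounds named here, compound 1 therefore stands where every measured compound stands, at the limit of > 225000 nM in this assay, at which 3 of the 3 values shown sit, and no measured compound gives a number inside the working range of the assay, so no step between any two of them can be read.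

Compound 4 `CN1CCC(C(=O)N2Cc3c(NC(=O)c4cccs4)n[nH]c3C2(C)C)CC1` has not yet been measured. It differs from compound 1 in one place: thiophen-2-yl in place of thiophen-3-yl on a carbonyl carbon. Because all three measured compounds sit at the limit of > 225000 nM in this assay, at which 3 of the 3 values shown sit, the step is expected to be none beyond the scatter, a step that the limit leaves unreadable from compound 1 to compound 4. Compound 4 is expected to be reported as a limit once more. For compound 4 the expected solubility is 250000 nM, with a range from 100000 nM to 500000 nM.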

Compound 4, solubility: 155000 nM
Compound 4: middle estimate off by 1.6-fold (0.21 log units), on the high side; the measured number falls inside the stated range.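

For the compounds shown here, compound 4 is the first compound here with a number inside the working range of this assay, so the group on this carbonyl carbon can now be tied to a real value rather than only to a limit. The exchange of thiophen-3-yl for thiophen-2-yl keeps the atoms and the counted features of the group the same, and it is recorded as an at least 1.4-fold lower number from compound 1 to compound 4 (0.16 log units; that floor lies within the scatter). That figure is only a floor, and the true size of the step stays unknown because the value of compound 1 is a limit of the assay, so the change cannot be said to lower the read-out by more than the scatter: the limit of > 225000 nM in this assay, at which 3 of the 4 values shown sit.

The compounds shown leave open how large the step between the two thiophene isomers really is, and no other step among them can be read. They also leave open what a furan-2-yl ring or a pyridine ring would give on this carbonyl carbon of the core of compound 1, and whether any such group would give a number or a limit.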